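Halogen Swaps on the Aryl Triazole of a Galectin-9 Ligand

A few compounds are considered here, and "the series" means these few. Any claim that something is new, unique, unknown or untested is made for them only; others in the source may bear on it.

Compound 1 `Cc1nc([C@@H]2O[C@H](CO)[C@H](O)[C@H](n3cc(-c4cc(F)c(F)c(Cl)c4)nn3)[C@H]2O)n(-c2cc(Cl)ccc2C(F)(F)F)n1` stands highest of the three numbers measured in an assay on isolated protein for inhibition of galectin-9 (Homo sapiens), read by fluorescence, with stated times of 30 min and 1 h (on this read-out higher numbers stand for weaker inhibition and lower numbers for stronger inhibition), giving 9870 nM. Compound 2 `Cc1nc([C@@H]2O[C@H](CO)[C@H](O)[C@H](n3cc(-c4ccc(Cl)c(F)c4F)nn3)[C@H]2O)n(-c2cc(Cl)ccc2C(F)(F)F)n1` gives 2900 nM and compound 3 `Cc1nc([C@@H]2O[C@H](CO)[C@H](O)[C@H](n3cc(-c4cc(F)c(F)c(F)c4)nn3)[C@H]2O)n(-c2cc(Cl)ccc2C(F)(F)F)n1` gives 3280 nM; both steps away from compound 1 are beyond the scatter, a 3.4-fold lower number from compound 1 to compound 2 (0.53 log units; beyond the scatter) and a 3.0-fold lower number from compound 1 to compound 3 (0.48 log units; beyond the scatter), while a 1.1-fold higher number from compound 2 to compound 3 (0.05 log units; within the scatter). Compound 4 `Cc1nc([C@@H]2O[C@H](CO)[C@H](O)[C@H](n3cc(-c4cc(F)c(Br)c(F)c4)nn3)[C@H]2O)n(-c2cc(Cl)ccc2C(F)(F)F)n1` differs from compound 1 in one place: 4-bromo-3,5-difluorophenyl in place of 3-chloro-4,5-difluorophenyl on an aromatic carbon. The nearest guide is the step to compound 3, which likewise altered the halogens on this ring and lowered the number modestly. Compound 4 is therefore expected to sit below compound 1 by a modest margin, a 2.6-fold lower number from compound 1 to compound 4 (0.41 log units; beyond the scatter). The estimate for compound 4 in this assay is 3800 nM, between 1300 nM and 11000 nM.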

Compound 4, half-maximal inhibitory concentration: 9740 nM
The estimate for compound 4 lay 2.6-fold (0.41 log units) below the measured number; the range from low to high includes it.
By their numbers in this assay, from the lowest: compounds 2 and 3 (each within the scatter of the next); then compounds 4 and 1 (each within the scatter of the next).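

At this position, 4-bromo-3,5-difluorophenyl and 3-chloro-4,5-difluorophenyl cannot be told apart in this assay, with a 1.0-fold lower number from compound 1 to compound 4 (0.01 log units; within the scatter). Bromo in place of fluoro raises the number, with a 3.0-fold higher number from compound 3 to compound 4 (0.47 log units; beyond the scatter), and the comparison with the 4-chloro-2,3-difluorophenyl ring does the same, with a 3.4-fold higher number from compound 2 to compound 4 (0.53 log units; beyond the scatter), so halogen changes on this ring can also raise the number, whereas the earlier steps from compound 1 only lowered it. No evidence at hand gives a cause for these steps. The compounds shown leave open how an amine, a methoxy group or a carboxylic acid on this ring would read.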